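The source may hold more compounds than are shown below. What is called first, only, known or untested is meant among the compounds shown, and "the series" means these compounds.

Measured compounds:
compound 1 `C/C=C/C=C/C(=O)N(Cc1ccc(OC)c(O)c1)c1cc(OC)c(OC)c(OC)c1` gives 140 nM in a functional assay on MGC-803 cells (Homo sapiens) for inhibition, read by MTT assay, with a stated time of 48 h; on this read-out higher numbers stand for weaker inhibition and lower numbers for stronger inhibition;
compound 2 `C/C=C/C(=O)N(Cc1ccc(OC)c([N+](=O)[O-])c1)c1cc(OC)c(OC)c(OC)c1` gives 590 nM in this assay.

Of the compounds shown here, two have been measured, and compound 1 stands with the lower of the two numbers, which on this read-out means the stronger inhibition. Compound 2 sits at a number that is beyond the usual scatter away from compound 1, so the two do differ. Among the compounds with values here, no pair of measured compounds differs in only one place, so no single change has yet been followed by the numbers.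

Compound 3 `COc1ccc(CN(C(=O)C(C)Br)c2cc(OC)c(OC)c(OC)c2)cc1O` has not been measured. It keeps the core of compound 1 and differs from it in one place:
1-bromoethyl in place of penta-1,3-dien-1-yl on a carbonyl carbon

Within the data shown here, with no measured step of this kind to lean on, the expectation has to be loose. The change takes away a longer unsaturated chain and puts in a short chain carrying a bromine, and the step is expected to be a moderate rise in the number, meaning weaker inhibition, beyond the scatter a 3.6-fold higher number from compound 1 to compound 3 (0.55 log units; beyond the scatter). Compound 3 is therefore estimated to give 500 nM in this assay, within a range from 150 nM to 2500 nM.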

Compound 3, half-maximal inhibitory concentration: 120 nM
The estimate for compound 3 lay 4.2-fold (0.62 log units) above the measured number; measured number outside the range, below it.
By their numbers in this assay, from the lowest: compounds 3 and 1 (each within the scatter of the next); then compound 2.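

In this assay, putting 1-bromoethyl in place of penta-1,3-dien-1-yl on a carbonyl carbon gives a 1.2-fold lower number from compound 1 to compound 3 (0.07 log units; within the scatter), so this pair cannot be told apart on this read-out. Within the data shown here, the earlier compounds could not show this, as neither of them was a one-place neighbour of another, and it is the first sign of how this position responds to a change: for this one pair, the longer chain with its two double bonds can leave and a shorter chain carrying a bromine can enter without a difference that exceeds the scatter. No measurement of any other kind is at hand to say why these two groups read alike.

From the compounds shown here alone, whether the bromine itself matters stays open, and a plain ethyl or a 1-chloroethyl group on the same carbonyl carbon would be the direct comparison with compound 3. How far this tolerance reaches is also unknown, as one pair cannot say how a longer saturated chain, a chain ending in an amine or one ending in a carboxylic acid would read at this position.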